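The compounds below may be only part of what the source reports. "The series", "measured", "known", "first", "only" and "open" are said of these compounds alone.

Compound 1 `Cc1cccc2c(=O)c(-c3nn[nH]n3)c[nH]c12`: > 5 mg/kg
Compound 2 `O=C(O)c1cnc2ccc(C3CCCCC3)cc2c1`: > 25 mg/kg
Compound 3 `CCc1ccc2[nH]cc(-c3nn[nH]n3)c(=O)c2c1`: < 5 mg/kg

Among the compounds with values here, every number so far comes from a functional assay on the whole organism (strain Sprague-Dawley) for inhibition, with Rattus norvegicus as the target; on this read-out higher numbers stand for an effect only at larger amounts of compound and lower numbers for an effect already at smaller amounts. Compound 1 sits at > 5 mg/kg, which is a limit of the assay rather than a number (the limit of > 5 mg/kg in this assay, at which 1 of the 3 values shown sits). Compound 3 shows < 5 mg/kg, again only a limit (the limit of < 5 mg/kg in this assay, at which 1 of the 3 values shown sits). Compound 2 shows > 25 mg/kg, likewise a limit (the limit of > 25 mg/kg in this assay, at which 1 of the 3 values shown sits). Compound 4 `O=c1c(-c2nn[nH]n2)c[nH]c2c(F)cccc12` arises from compound 1 through a single change: fluoro in place of methyl on an aromatic carbon. Within the data shown here, no step between two measured compounds covers this change, so nothing measured indicates its size. Since compound 1 itself gives only the limit > 5 mg/kg, the step is expected to be small, toward larger doses or none beyond the scatter, and is estimated as a step that the limit leaves unreadable from compound 1 to compound 4. Compound 4 is accordingly expected near 10 mg/kg, within 3 mg/kg to 30 mg/kg.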

Compound 4, minimum effective dose: 0.625 mg/kg
The estimate for compound 4 lay 16-fold (1.20 log units) above the measured number; the measured number lies below the stated range.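

Fluoro in place of methyl on an aromatic carbon is the only change here that can be read in one place, and in this assay it gives an at least 8.0-fold lower number from compound 1 to compound 4 (0.90 log units; beyond the scatter). What sits on this carbon therefore matters to the dose needed, with a step beyond the usual scatter. The full size of the step stays unknown because compound 1 gives only a limit of the assay: the limit of > 5 mg/kg in this assay, at which 1 of the 4 values shown sits.

As far as these compounds go, whether a chloro or a methoxy group on this carbon would give a lower number remains open. So does whether fluoro on another aromatic carbon of the shared core would match compound 4.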